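Methoxy for methyl on the aniline ring of compound 2

The source may report more compounds than this note shows. Statements on the series, on what has been measured and on what is new or still open speak of the compounds shown alone.

Measured so far in a functional assay on HCC827 cells (Homo sapiens) for inhibition, read by MTT assay, with a stated time of 48 h, tested at 10 uM; on this read-out lower numbers stand for less inhibition and higher numbers for more inhibition at the one concentration tested (going by the name of the read-out):
Compound 1 `Cc1ccc(Nc2cc(NC(=O)Nc3c(Cl)cccc3Cl)ncn2)cc1F` gives 85.3%.
Compound 2 `Cc1ccc(Nc2cc(NC(=O)Nc3c(Cl)cccc3Cl)ncn2)cc1C` gives 84.3%.
Compound 3 `COc1cc(NC(=O)Nc2cc(Nc3ccc(C)c(C)c3)ncn2)cc(OC)c1` gives 45.7%.

Compound 2 stands second highest of the three numbers, its nearest neighbour being compound 1, whose number lies within the scatter of that of compound 2; compound 3 lies far below both. Going by the values given here, the only step between measured compounds that differ in one place is a number 1 percentage points lower from compound 1 to compound 2 (within the scatter), a change of one small group on the same aromatic ring that is touched again here, and it stayed within the scatter. Among the compounds with values here, compound 3 differs from compound 2 on the other ring of the shared core and is not a single-place step; its two values show only that a change there cost much inhibition.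

The unmeasured compound 4 `COc1ccc(Nc2cc(NC(=O)Nc3c(Cl)cccc3Cl)ncn2)cc1C` arises from compound 2 by methoxy in place of methyl on an aromatic carbon. Within the data shown here, the one measured step on this ring bears on it and was within the scatter, so for compound 4 a step in this assay of at most modest size is expected, more likely downward than upward, given that no measured step supports a gain. Compound 4 is therefore expected to give 78%, within 60% to 90%, which would mean an expected step of a number 6.3 percentage points lower from compound 2 to compound 4 (within the scatter).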

Compound 4, a percentage reported as inhibition, at one concentration (the size of the read-out at that concentration, not a potency): 63.1%
The estimate for compound 4 lay 14.9 percentage points above the measured number; low and high end bracket the measured number.
By their numbers in this assay, from the lowest: compound 3; then compound 4; then compounds 2 and 1 (each within the scatter of the next).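

In this assay, methoxy in place of methyl on the aromatic carbon para to a large group gives a number 21.2 percentage points lower from compound 2 to compound 4 (beyond the scatter), whereas the earlier change on this ring, at its other substituted carbon, gave only a number 1 percentage points lower from compound 1 to compound 2 (within the scatter). The two carbons of this ring therefore do not respond alike: fluoro and methyl are interchangeable at one within the scatter, but methoxy for methyl at the other costs inhibition, and the change from 3-fluoro-4-methylphenyl to 4-methoxy-3-methylphenyl, which alters both carbons at once, gives a similar a number 22.2 percentage points lower from compound 1 to compound 4 (beyond the scatter). Nothing available here accounts for this loss.

A single replacement cannot show whether the loss follows the oxygen of the methoxy group or the larger group as a whole, and an ethyl, a hydroxy or a chlorine at this carbon would help separate the two. As far as these compounds go, it also remains open whether an amine or a longer ether chain here would lower the number further, and whether methoxy at the other substituted carbon of the ring would be met as mildly as fluoro and methyl were.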